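The source may hold more compounds than are shown below. What is called first, only, known or untested is meant among the compounds shown, and "the series" means these compounds.

Compound 1 `OC(CCn1nc2c(Br)c(Br)c(Br)c(Br)c2n1)c1ccc(F)cc1` is one of three measured compounds that share a core and differ only in the group on a saturated chain carbon bound to an oxygen on a saturated carbon and a saturated chain carbon. In a functional assay on CCRF-CEM cells (Homo sapiens) for antiproliferative activity, read by MTT assay, with a stated time of 48 h, tested at 50 uM (a higher number here means a weaker effect of the compound at the concentration tested, a lower number a stronger effect), compound 1 gives 0%. Compound 3 `OC(CCn1nc2c(Br)c(Br)c(Br)c(Br)c2n1)c1cccc(Cl)c1` gives 0% in this assay, and compound 2 `COc1cccc(C(O)CCn2nc3c(Br)c(Br)c(Br)c(Br)c3n2)c1` gives 2%. Compound 1 thus stands level with compound 3, the two together being the lowest of the three numbers; its nearest neighbour is compound 3, with no change at the digits printed from compound 1 to compound 3 (within the scatter), and its furthest is compound 2, with a number 2 percentage points higher from compound 1 to compound 2 (within the scatter). Between the other two, a number 2 percentage points lower from compound 2 to compound 3 (within the scatter).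

Compound 4 `CC(O)CCn1nc2c(Br)c(Br)c(Br)c(Br)c2n1` differs from compound 1 in one place: methyl in place of 4-fluorophenyl on a saturated chain carbon bound to an oxygen on a saturated carbon and a saturated chain carbon. The three measured steps each exchange one six-membered aromatic ring for another at this place, and all stay within the scatter; none removes the ring altogether, so they bear on this change only loosely. Since every measured number sits near the floor, it is expected that compound 4 will also show a step of a number 1 percentage points higher from compound 1 to compound 4 (within the scatter), nothing beyond the scatter. Compound 4 is therefore estimated at 1% in this assay, within a range from 0% to 12%.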

Compound 4, a percentage reported as activity, at one concentration (the size of the read-out at that concentration, not a potency): 45%
The estimate for compound 4 lay 44 percentage points below the measured number; measured number outside the range, above it.
By their numbers in this assay, from the lowest: compounds 1, 3 and 2 (each within the scatter of the next); then compound 4.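

In this assay, swapping one six-membered aromatic ring for another had left the number flat, but removing the ring altogether is a different matter: methyl in place of 4-fluorophenyl gives a large step (a number 45 percentage points higher from compound 1 to compound 4 (beyond the scatter)). The same holds for the other two rings (a number 45 percentage points higher from compound 3 to compound 4 (beyond the scatter)) and (a number 43 percentage points higher from compound 2 to compound 4 (beyond the scatter)), so the outcome does not depend on which of the three substituted rings is lost. At this place, then, all three ring-bearing compounds show a stronger effect at the tested concentration than compound 4, which the earlier ring-for-ring exchanges could not reveal. Nothing measured here explains this difference.

From the compounds shown here alone, whether a cyclohexyl ring or a longer chain such as butyl would stay close to the ring-bearing compounds or fall back towards compound 4 remains open. So does whether an unsubstituted phenyl group would behave like the three substituted rings.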